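Fluoro on the benzoyl ring of compound 1

The source may report more compounds than this note shows. Statements on the series, on what has been measured and on what is new or still open speak of the compounds shown alone.

- Compound 1 (`O=C(CC1S/C(=N\N=C\c2c(-c3ccccc3)[nH]c3ccccc23)NC1=O)c1ccccc1`) with > 50000 nM as a limit
- Compound 2 (`CCOC(=O)c1sc(N/N=C/c2c(-c3ccc([N+](=O)[O-])cc3)[nH]c3ccccc23)nc1C`) with 23500 nM as a number

Both readings come from an ADME assay on MRC5 cells (Homo sapiens) for cytotoxicity, read by fluorescence, with a stated time of 24 h (on this read-out higher numbers stand for weaker inhibition and lower numbers for stronger inhibition), and compound 1 stands at the limit of that read-out and not on a number (the limit of > 50000 nM in this assay, at which 1 of the 2 values shown sits). Compound 3 (`O=C(CC1S/C(=N\N=C\c2c(-c3ccccc3)[nH]c3ccccc23)NC1=O)c1ccc(F)cc1`) departs from compound 1 by a single change (fluoro in place of hydrogen on an aromatic carbon), fluoro in place of hydrogen on an aromatic carbon, which turns benzoyl into (4-fluorophenyl)carbonyl. Among the measured compounds shown here, no measured pair shows this change. The expected step (a number no higher from compound 1 to compound 3 (the limit leaves the size open)) stays within the usual scatter of this assay with no direction favoured. That expectation rests only on compound 1 with its limit of > 50000 nM and another limit is the likeliest report. Compound 3 is estimated at 50000 nM (22000 nM to 100000 nM).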

Compound 3, half-maximal inhibitory concentration: 49800 nM
Estimate against measurement, compound 3: 1.0-fold (0.00 log units) above; the range from low to high includes it.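

In this assay compound 3, which carries the (4-fluorophenyl)carbonyl group, gives 49800 nM, so this position now has a number on this read-out. Compound 1 gives > 50000 nM, which is a limit and not a number. Fluoro in place of hydrogen gives a number no higher from compound 1 to compound 3 (the limit leaves the size open), and the size of that step cannot be read because the reading for the benzoyl compound rests on a limit: the limit of > 50000 nM in this assay, at which 1 of the 3 values shown sits.

The compounds shown leave open what a chloro, a methoxy or an amine on the same aromatic carbon would give in this assay. Compound 2 differs from compound 1 and compound 3 in more than one place, so it offers no comparison for this change.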